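From Dimethoxyphenyl to Furanyl on a Saturated Ring Carbon

The source may hold more compounds than are shown below. What is called first, only, known or untested is meant among the compounds shown, and "the series" means these compounds.

Compound 2 `COc1ccc([C@@H]2CC(c3cccc(O)c3)=NN2c2ccc(S(N)(=O)=O)cc2)cc1OC` stands higher of the two measured compounds: in a functional assay on the whole organism (strain Wistar albino) for inhibition, with Rattus norvegicus as the target, read by paw edema, with stated times of 30 min and 3 h, at a dose of 0.05 mmol/kg (on this read-out lower numbers stand for less inhibition and higher numbers for more inhibition at the one dose given (going by the name of the read-out)), compound 2 gives 55.9%. Compound 1 `NS(=O)(=O)c1ccc(N2N=C(c3cccc(O)c3)C[C@H]2c2ccccc2O)cc1` gives 35.4% in this assay, and the step of a number 20.5 percentage points higher from compound 1 to compound 2 (beyond the scatter) shows that exchanging the group on this saturated ring carbon moves the number. Compound 3 `NS(=O)(=O)c1ccc(N2N=C(c3cccc(O)c3)C[C@H]2c2ccco2)cc1` differs from compound 2 by furan-2-yl in place of 3,4-dimethoxyphenyl on a saturated ring carbon. For the measured compounds named here, no measured step covers this particular exchange; the single known step only shows that this position carries modest weight. Compound 3 is therefore expected to come out somewhat lower, at about 42% (range 27% to 58%), an estimated step of a number 13.9 percentage points lower from compound 2 to compound 3 (beyond the scatter).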

Compound 3, a percentage reported as inhibition, in the whole organism at one dose (the size of the read-out at that dose, not a potency): 35.8%
Estimate against measurement, compound 3: 6.2 percentage points above; measured number inside the range.
By their numbers in this assay, from the lowest: compounds 1 and 3 (each within the scatter of the next); then compound 2.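

In this assay the exchange gives a number 20.1 percentage points lower from compound 2 to compound 3 (beyond the scatter) on this saturated ring carbon, so the higher number of compound 2 does not carry over to furan-2-yl. For the compounds shown here, the exchange of 2-hydroxyphenyl for furan-2-yl gives a number 0.4 percentage points higher from compound 1 to compound 3 (within the scatter) and so leaves the number unmoved, which makes 3,4-dimethoxyphenyl the only one of these three groups that stands apart. Nothing available here explains this difference.

On these data alone, what remains open is whether the higher number needs both methoxy groups, which a plain phenyl or a 4-methoxyphenyl group could help to settle. As far as these compounds go, how an amine or a longer alkyl chain on this carbon would read also remains unknown.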